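A few compounds are considered here, and "the series" means these few. Any claim that something is new, unique, unknown or untested is made for them only; others in the source may bear on it.

Measured so far:
compound 1, `CC(c1ccc(-c2ccccc2)c(F)c1)c1nnc2n1N=C(c1ccc(Cl)cc1)CS2`: 3900 nM
compound 2, `CC(C)Cc1ccc(C(C)c2nnc3n2N=C(c2ccc([N+](=O)[O-])cc2)CS3)cc1`: "not active" (no number reported)

Going by the values given here, compound 1 gives the only numerical reading in a functional assay on Huh-7 cells (Homo sapiens) for inhibition, read by sulforhodamine B assay, with a stated time of 72 h; a higher number here means a weaker inhibitor, a lower number a stronger inhibitor. The other entry, compound 2, is reported only as "not active" (no number reported), so compound 1 cannot be ranked against it on the numbers shown. Compound 3, `CC(c1ccc(-c2ccccc2)c(F)c1)c1nnc2n1N=C(c1ccc([N+](=O)[O-])cc1)CS2`, is not yet measured. It differs from compound 1 in one place: nitro in place of chloro on an aromatic carbon. Among the compounds with values here, no pair of measured compounds differs by this change alone, so its size has to be guessed. Compound 2 also carries the 4-nitrophenyl on the shared core, though with a different group on the other side, and in this assay compound 2 gave "not active" (no number reported); compound 1, with the 4-chlorophenyl, gave 3900 nM. On that thin basis a loss of potency on going from chloro to nitro is expected, of modest size, with a real chance that compound 3 also returns no number. The step from compound 1 to compound 3 is expected to be a 2.3-fold higher number from compound 1 to compound 3 (0.36 log units; beyond the scatter). Compound 3 is estimated at 9000 nM, range 3000 nM to 30000 nM.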

Compound 3, half-maximal inhibitory concentration: 4300 nM
Compound 3: the middle estimate sits 2.1-fold (0.32 log units) above what was measured; low and high end bracket the measured number.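

Working from the 4-chlorophenyl to the 4-nitrophenyl on the shared core in this assay gives a 1.1-fold higher number from compound 1 to compound 3 (0.04 log units; within the scatter) and so the two readings cannot be told apart, which shows that this aromatic carbon, para to a large group, accepts nitro in place of chloro with the activity kept. Compound 3 gives 4300 nM while carrying the 4-nitrophenyl, so that group does not by itself go with a missing number, and the "not active" entry of compound 2, which carries it too, cannot be pinned on it; compound 2 differs from compound 3 in the group on the other side of the shared core. Nothing at hand accounts for the two readings lying so close together.

The compounds shown leave open whether an amine, a carboxylic acid or a methoxy group at this same aromatic carbon would read like chloro and nitro, or whether a plain unsubstituted phenyl would do so. They also leave open whether chloro in place of nitro would give compound 2 a numerical reading.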